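This account rests on a few compounds, and the source may have more. Where it says the series, first, only, none or still open, it means among the compounds named here.

Compound 1 `COC(=O)c1ccc2c(ccn2-c2cccc(NC(=O)Nc3ccc(Cl)c(C(F)(F)F)c3)c2)n1`, compound 2 `O=C(Nc1ccc(-n2ccc3nc(C(=O)NCc4ccccc4)ccc32)cc1)Nc1cccc(Cl)c1Cl` and compound 3 `NC(=O)c1ccc2c(ccn2-c2ccc(NC(=O)Nc3ccc(Cl)c(Cl)c3)cc2)n1` were each tested in an ADME assay on HS27 cells (Homo sapiens) for cytotoxicity, read by MTT assay; on this read-out higher numbers stand for weaker inhibition and lower numbers for stronger inhibition. For compound 1 the assay reports only a limit, > 10000 nM. For compound 2 the assay likewise reports only a limit, > 10000 nM. Compound 3 gives a number in this assay, 6600 nM. Compound 2 therefore stands at the limit of > 10000 nM in this assay, at which 2 of the 3 values shown sit, so no number places it against the other two compounds.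

Compound 4 `O=C(Nc1ccc(-n2ccc3nc(C(=O)NCc4ccccc4)ccc32)cc1)Nc1ccc(Cl)c(C(F)(F)F)c1` has not yet been measured in this assay. It differs from compound 2 in one place: 4-chloro-3-(trifluoromethyl)phenyl in place of 2,3-dichlorophenyl on an amide-type nitrogen. Among the compounds with values here, no measured pair differs in just this way, so the size of the step cannot be read from a measured step. Compound 1, which carries the same 4-chloro-3-(trifluoromethyl)phenyl group on an amide-type nitrogen, also reached only a limit in this assay, and nothing seen here points to a move away from the limit.

The step from compound 2 to compound 4 in this assay is expected to be a step that the limit leaves unreadable from compound 2 to compound 4, which is to say nothing beyond the usual scatter. For compound 4 the estimated value in this assay is 15000 nM, with a range from 5000 nM to 45000 nM, and the assay is expected most likely to report only a limit once more.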

Compound 4, half-maximal inhibitory concentration: 3000 nM
For compound 4 the middle estimate is 5.0-fold (0.70 log units) above the measured one; measured number outside the range, below it.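

In this assay, the group on the amide-type nitrogen proves able to shift the read-out: with the rest of the structure unchanged, 4-chloro-3-(trifluoromethyl)phenyl in place of 2,3-dichlorophenyl gives an at least 3.3-fold lower number from compound 2 to compound 4 (0.52 log units; beyond the scatter). A change confined to this one group is thus enough to give a measured number, with compound 4 at 3000 nM. The full size of the step cannot be read, because compound 2 stands at a limit: the limit of > 10000 nM in this assay, at which 2 of the 4 values shown sit.

The compounds shown do not tell whether the trifluoromethyl group or the placing of the chlorine carries the step, which a plain 4-chlorophenyl or 3-(trifluoromethyl)phenyl group would help to separate. They also leave open how this group would read with a carboxylic acid on the shared core.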